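Adding a sulfamoyl group to compound 1

A few compounds are considered here, and "the series" means these few. Any claim that something is new, unique, unknown or untested is made for them only; others in the source may bear on it.

Compound 1 `Nc1nc(Nc2ccccc2)sc1C(=O)c1cccnc1` gives 5900 nM 
Compound 2 `Nc1nc(Nc2ccccc2)sc1C(=O)c1ccc(F)cc1` gives 16000 nM 
Compound 3 `NC(=O)c1sc(Nc2ccccc2)nc1N` gives > 60000 nM as a limit

Among the actual numbers in a functional assay on GC-1 cells (Mus musculus) for cytotoxicity, read by MTT assay, with a stated time of 72 h (on this read-out lower numbers stand for stronger inhibition and higher numbers for weaker inhibition), compound 1 is the lowest at 5900 nM in this small set. Compound 4 `Nc1nc(Nc2ccc(S(N)(=O)=O)cc2)sc1C(=O)c1cccnc1` differs from it by sulfamoyl in place of hydrogen on an aromatic carbon, with the sulfamoyl group para to a large group. The measured steps, a 2.7-fold higher number from compound 1 to compound 2 (0.43 log units; beyond the scatter) and an at least 10-fold higher number from compound 1 to compound 3 (1.00 log units; beyond the scatter), both alter the group on the carbonyl carbon, so neither tests this new place. They show only how far this assay can move. Within the data shown here, no measured step sets the direction, so a modest step to a lower number is only a cautious expectation. The estimate amounts to a 2.4-fold lower number from compound 1 to compound 4 (0.37 log units; beyond the scatter) overall. Compound 4 is expected at 2500 nM, within an estimated range from 250 nM to 20000 nM overall.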

Compound 4, half-maximal inhibitory concentration: 20000 nM
For compound 4 the middle estimate is 8.0-fold (0.90 log units) below the measured one; low and high end bracket the measured number.
By their numbers in this assay, from the lowest: compound 1; then compounds 2 and 4 (each within the scatter of the next). At a limit, above all of these: compound 3.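

Until now, every measured step changed the group on the carbonyl carbon; this one shows that the other end of the molecule also matters. In this assay, sulfamoyl in place of hydrogen on the six-membered aromatic ring gives a 3.4-fold higher number from compound 1 to compound 4 (0.53 log units; beyond the scatter), so inhibition weakens at this place, but only modestly. Nothing shown here explains this step.

Going by these compounds, with a single group at this place, it remains open whether sulfamoyl itself weakens inhibition or whether any addition there would. A methyl group, an amine or a carboxylic acid at the same place could separate these possibilities.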